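A Weak Growth Inhibitor Gets a New Aromatic Group

The source may hold more compounds than are shown below. What is called first, only, known or untested is meant among the compounds shown, and "the series" means these compounds.

In a functional assay on SNB-75 cells (Homo sapiens) for inhibition, read by sulforhodamine B assay, with a stated time of 48 h (a lower number here means a stronger inhibitor of growth, a higher number a weaker inhibitor of growth), compound 1 `O=C(Cc1csc2nc(-c3ccc(Br)cc3)cn12)N/N=C/c1ccccc1` gives 89100 nM. For compound 2 `O=C(Cc1csc2nc(-c3ccc(Br)cc3)cn12)N/N=C/c1ccc(O)cc1`, the assay reports only a limit, > 100000 nM, so this value is not an exact number. The same limit applies to the limit of > 100000 nM in this assay, at which 1 of the 2 values shown sits.

Compound 3 `COc1cccc(OC)c1/C=N/NC(=O)Cc1csc2nc(-c3ccc(Br)cc3)cn12` has not yet been measured. The change is 2,6-dimethoxyphenyl in place of 4-hydroxyphenyl on a carbon with a double bond to nitrogen. Going by the values given here, only one measured step bears on this swap. It places hydroxy in place of hydrogen on an aromatic carbon and is recorded as an at least 1.1-fold higher number from compound 1 to compound 2 (0.05 log units; that floor lies within the scatter). That step concerns a smaller change than the one now being made, so it serves only as a loose guide. With so little evidence, the best anchor is the weak value of compound 1, 89100 nM. No step beyond the scatter is therefore expected in this assay, and the estimated step is an at least 1.2-fold lower number from compound 2 to compound 3 (0.09 log units; that floor lies within the scatter). For compound 3, the estimated value is 80000 nM, with an expected range from 40000 nM to 100000 nM.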

Compound 3, concentration for total growth inhibition: 66100 nM
Compound 3: the middle estimate sits 1.2-fold (0.08 log units) above what was measured, and the stated range covers the measured number.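

Replacing phenyl with 2,6-dimethoxyphenyl on the carbon with a double bond to nitrogen gives a 1.3-fold lower number from compound 1 to compound 3 (0.13 log units; within the scatter) in this assay, so this position accepts a ring carrying two methoxy groups with no difference that can be told from repeat scatter, and growth inhibition remains weak. Going by these compounds alone, the swap from 4-hydroxyphenyl to 2,6-dimethoxyphenyl, which removes the one hydrogen-bond donor of the leaving group, gives an at least 1.5-fold lower number from compound 2 to compound 3 (0.17 log units; that floor lies within the scatter), and this is the first step that starts from a substituted ring rather than from plain phenyl. Compound 2 stands at a limit and not at an exact number, so that step can be read only as a floor: the limit of > 100000 nM in this assay, at which 1 of the 3 values shown sits.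

As far as these compounds go, whether any group on this ring can shift the number beyond the scatter remains open, since neither step read with a full value or a floor here clears it. An amine or a carboxylic acid on the ring, or a longer chain in its place, would show whether this position can respond at all in this assay, or whether the shared core alone sets the weak growth inhibition seen so far.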